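Adding bromo to a compound at the assay limit

This account rests on a few compounds, and the source may have more. Where it says the series, first, only, none or still open, it means among the compounds named here.

In a functional assay on CCRF-CEM cells (Homo sapiens) for cytotoxicity, read by cell counting, with a stated time of 72 h (on this read-out higher numbers stand for weaker inhibition and lower numbers for stronger inhibition), compound 1 `Clc1ncc2sccc2n1` gives > 250000 nM as a limit of the assay and not a number. Compound 2 `Nc1nc(Cl)nc2ccsc12` gives > 250000 nM as a limit too. So far the record holds only the limit of > 250000 nM in this assay, at which 2 of the 2 values shown sit, and no actual number. Among the compounds with values here, the one measured step is a step that the two limits leave unreadable from compound 1 to compound 2 and gives no size to carry forward.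

Compound 3 `Nc1nc(Cl)nc2c(Br)csc12` is compound 2 with bromo in place of hydrogen on an aromatic carbon, a change counted as bromo in place of hydrogen on an aromatic carbon and nothing else. With no measured size to lean on, any expectation has to stay loose, and another limit is quite possible. The estimated at least 5.0-fold lower number from compound 2 to compound 3 (0.69 log units; beyond the scatter) in this assay points toward stronger inhibition, if a number is reported at all. For compound 3 the expected value is 50000 nM with 5000 nM and 250000 nM as the ends of its range.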

Compound 3, half-maximal inhibitory concentration: 109000 nM
Beside the measured number, compound 3's estimate is 2.2-fold (0.34 log units) below it, and the stated range covers the measured number.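

In this assay, bromo in place of hydrogen on an aromatic carbon, two ring bonds from the ring sulfur, brings an at least 2.2-fold lower number from compound 2 to compound 3 (0.36 log units; beyond the scatter). Within the data shown here, this shows that the position responds to a single added bromine atom, which the earlier compounds could not show, and compound 3 is the first compound here with an actual number rather than a limit. The size of the step remains open-ended, as the starting point for compound 2 is only a limit, and limits still make up most of this short record: the limit of > 250000 nM in this assay, at which 2 of the 3 values shown sit.

The compounds shown leave open whether this gain belongs to bromo alone or would also appear with chloro, methyl or methoxy on the same carbon. They also leave open whether bromo would bring a similar step to compound 1, which carries no amino group.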